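The source may hold more compounds than are shown below. What is called first, only, known or untested is meant among the compounds shown, and "the series" means these compounds.

In an ADME assay on HEK-293T cells (Homo sapiens) for cytotoxicity, read by luminescence, with a stated time of 24 h (on this read-out lower numbers stand for higher toxicity in this test and higher numbers for lower toxicity in this test), two compounds with a shared core have been measured. Compound 1 `CCOC(=O)c1cc2sccc2n1Cc1ccc(OC)cc1` gives > 100000 nM, which is a limit of the assay. Compound 2 `COc1ccc(Cn2c(C(=O)NC(C)c3ccccc3)cc3sccc32)cc1` gives > 100000 nM, also a limit and not a number, so its place can only be stated as the limit of > 100000 nM in this assay, at which 2 of the 2 values shown sit.

Compound 3 `CCN(CC)C(=O)c1cc2sccc2n1Cc1ccc(OC)cc1` carries diethylamino in place of (1-phenylethyl)amino on a carbonyl carbon. Among the compounds with values here, the one measured step that bears on this change is a step that the two limits leave unreadable from compound 1 to compound 2, which exchanges a group on the same carbonyl carbon. Its size cannot be read, so it offers no measured size to carry over.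

The expectation therefore rests on compound 2 and its limit of > 100000 nM. The expected result is a number no higher from compound 2 to compound 3 (the limit leaves the size open), with no step beyond the scatter and no direction foreseen. For compound 3 the estimate is 100000 nM, with an expected range from 40000 nM to 200000 nM.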

Compound 3, half-maximal cytotoxic concentration: > 100000 nM
Compound 3: only a limit was reported; the forecaster's own chance of this, stated with the estimate: 85%; the middle value sits exactly at the limit.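

In this assay, within the data shown here, compound 3 gives > 100000 nM, again a limit of the assay, so no step among compound 1, compound 2 and compound 3 can be read. The compounds shown leave open whether any group on the carbonyl carbon changes this read-out at all.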